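Swapping Acetyl for Chloro in a Cytotoxicity Series

A few compounds are considered here, and "the series" means these few. Any claim that something is new, unique, unknown or untested is made for them only; others in the source may bear on it.

Compound 1, `C=C1CC[C@@H](C(C)C)[C@]12CC=C(C=O)CC2`: 269000 nM
Compound 2, `C=C1CCC[C@]2(C)CCC(c3cn(-c4ccc(C(C)=O)cc4)nn3)=CC[C@@]12C`: 15100 nM

In a functional assay on HeLa cells (Homo sapiens) for cytotoxicity, read by MTT assay, with a stated time of 48 h (a lower number here means a stronger inhibitor, a higher number a weaker inhibitor), compound 1 gives 269000 nM, while compound 2 gives 15100 nM. Compound 2 thus holds the lowest of the two numbers, and its gap to compound 1 lies beyond the usual scatter.

Compound 3, `C=C1CCC[C@]2(C)CCC(c3cn(-c4ccc(Cl)cc4)nn3)=CC[C@@]12C`, differs from compound 2 by chloro in place of acetyl on an aromatic carbon. Among the compounds with values here, no measured pair shows this kind of exchange, so the expected step of a 1.0-fold lower number from compound 2 to compound 3 (0.00 log units; within the scatter) is small and may not exceed the scatter. Compound 3 is therefore estimated at 15000 nM, with a range from 5000 nM to 45000 nM.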

Compound 3, half-maximal inhibitory concentration: 18800 nM
Compound 3: middle estimate off by 1.3-fold (0.10 log units), on the low side, and the stated range covers the measured number.
By their numbers in this assay, from the lowest: compounds 2 and 3 (each within the scatter of the next); then compound 1.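

In this assay, chloro in place of acetyl on the aromatic carbon para to a large group gives a 1.2-fold higher number from compound 2 to compound 3 (0.10 log units; within the scatter). Within the data shown here, this is the first direct reading at this position: a single chlorine atom and the three heavy atoms of acetyl, including its hydrogen-bond acceptor, give values within the scatter of each other. Nothing measured here explains this match. Two groups cannot define what this position accepts. From the compounds shown here alone, how an amine, a carboxylic acid or a longer chain on the same carbon would read in this assay remains open.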